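Two Limits and an Iodine Swap

The source may hold more compounds than are shown below. What is called first, only, known or untested is meant among the compounds shown, and "the series" means these compounds.

- Compound 1 `CCc1ccc(-c2nc3c(c(C)nn3-c3ccccc3)c(-c3ccccc3[N+](=O)[O-])c2C#N)cc1` with > 20000 nM as a limit
- Compound 2 `Cc1cccc(-c2nc3c(c(C)nn3-c3ccccc3)c(-c3ccccc3O)c2C#N)c1` with > 20000 nM as a limit

In an ADME assay on BJ cells (Homo sapiens) for cytotoxicity, with a stated time of 72 h (on this read-out higher numbers stand for an effect only at larger amounts of compound and lower numbers for an effect already at smaller amounts), compound 2 stands at > 20000 nM which is a limit and not a number. Compound 1 gives > 20000 nM which is likewise a limit. The record so far is the limit of > 20000 nM in this assay, at which 2 of the 2 values shown sit, and it holds no graded value. Compound 3 `Cc1nn(-c2ccccc2)c2nc(-c3ccc(I)cc3)c(C#N)c(-c3ccccc3O)c12` differs from compound 2 by 4-iodophenyl in place of 3-methylphenyl on an aromatic carbon and the rest of the structure is unchanged. Among the compounds with values here, no measured pair shows what such a swap does, so no step beyond the scatter is expected in this assay and no direction is favoured. The estimated step is a number no higher from compound 2 to compound 3 (the limit leaves the size open) and a further limit is the likeliest report. Compound 3 is estimated at 20000 nM with 9000 nM as the expected lower end and 30000 nM as the upper end.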

Compound 3, half-maximal effective concentration: 19000 nM
Beside the measured number, compound 3's estimate is 1.1-fold (0.02 log units) above it; low and high end bracket the measured number.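

In this assay compound 3 gives 19000 nM, the only graded value among the compounds shown, so this aromatic carbon, next to the ring nitrogen and ortho to a cyano group, now has one number attached to it. On these data alone, putting 4-iodophenyl in place of 3-methylphenyl there gives an at least 1.0-fold lower number from compound 2 to compound 3 (0.02 log units; that floor lies within the scatter), but this is only a floor within the scatter, and the true size of the step stays open. The swap therefore places a graded value in the assay without showing a real shift, and the limit still accounts for most of the record: the limit of > 20000 nM in this assay, at which 2 of the 3 values shown sit.

The compounds shown do not separate the effect of the iodine from that of the methyl group's removal. They also leave open what an amine or a carboxylic acid on this phenyl ring would give.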